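A few compounds are considered here, and "the series" means these few. Any claim that something is new, unique, unknown or untested is made for them only; others in the source may bear on it.

Compound 2 `Cc1nc(C)n(CC(=O)N2CCN(c3sc(C(F)(F)F)nc3-c3nc4ccccc4[nH]3)C[C@H]2C)n1` has been measured in a physicochemical assay for solubility, in simulated intestinal fluid; a lower number here means a less soluble compound, a higher number a more soluble compound. In this assay compound 2 gives > 850 ug/mL, which is a limit of the assay rather than a number, so compound 2 stands at the top of what the assay can report. Compound 1 `Cc1nc(C)n(CC(=O)N2CCN(c3sc(C(F)(F)F)nc3-c3nc4ccc(C5CCOCC5)cc4[nH]3)C[C@H]2C)n1` carries an oxan-4-yl group on the shared core; in this assay compound 1 gives > 1000 ug/mL, again a limit and not a number. Compound 3 `C[C@@H]1CN(c2sc(C(F)(F)F)nc2-c2nc3ccccc3[nH]2)CCN1C(=O)Cn1cnc2cccnc21` differs from compound 2 on the carbon bound to the carbonyl, and in this assay compound 3 gives 214 ug/mL.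

Compound 4 `Cc1nc(C)n(CC(=O)N2CCN(c3sc(C(F)(F)F)nc3-c3nc4ccc(C5CCN(C)CC5)cc4[nH]3)C[C@H]2C)n1` differs from compound 2 by 1-methylpiperidin-4-yl in place of hydrogen on an aromatic carbon. The step most like this change is a step that the two limits leave unreadable from compound 1 to compound 2, whose size cannot be read because the limit of > 1000 ug/mL in this assay, at which 1 of the 3 values shown sits, and the limit of > 850 ug/mL in this assay, at which 1 of the 3 values shown sits, cap both ends. The step of an at least 3.9-fold lower number from compound 2 to compound 3 (0.59 log units; beyond the scatter) concerns a different part of the molecule and lowered the number. Since compound 1, which carries a ring of similar size at the same place, sits at its limit, and compound 2 sits at its limit, the expected step that the limit leaves unreadable from compound 2 to compound 4 is none beyond the scatter. Compound 4 is therefore estimated at 1000 ug/mL, expected to fall between 400 ug/mL and 2000 ug/mL.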

Compound 4, solubility: > 1020 ug/mL
Compound 4 gave a limit, no number; the forecaster's own chance of this, stated with the estimate: 70%; at least 1.0-fold (0.00 log units) between middle value and limit.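

In this assay compound 4 gives > 1020 ug/mL, a limit of the assay and not a number. Compound 1 and compound 2 also stand at limits, so no step among these three compounds can be read. The compounds shown leave open whether 1-methylpiperidin-4-yl or oxan-4-yl, in place of hydrogen on an aromatic carbon, changes the solubility at all.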